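Swapping a pyridinyl for a chlorophenyl on a shared aromatic core

This account rests on a few compounds, and the source may have more. Where it says the series, first, only, none or still open, it means among the compounds named here.

This account follows three measured compounds and one that is not yet measured. Compound 1 `Clc1ccc(-c2cc(-c3cccnc3)nc(-c3cccs3)c2)o1` gives 22300 nM in a functional assay on K562 cells (Homo sapiens) for cytotoxicity, in the presence of a further agent that is not named here; a higher number here means a weaker inhibitor, a lower number a stronger inhibitor. Among the three numbers it stands second highest. Among the measured compounds shown here, compound 3 `Clc1ccc(-c2cc(-c3cccnc3)nc(-c3ccsc3)c2)o1` lies nearest, with 21700 nM; the step of a 1.0-fold lower number from compound 1 to compound 3 (0.01 log units; within the scatter) is the only measured change of one place, and it lies within the scatter. For the measured compounds named here, compound 2 `Cc1ccc(-c2cc(-c3ccoc3)cc(-c3ccsc3)n2)cc1` is furthest, with 47800 nM, a number beyond the scatter from that of compound 1, but no single-place step connects it to the others.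

Compound 4 `Clc1ccc(-c2cc(-c3ccc(Cl)o3)cc(-c3cccs3)n2)cc1` is made from compound 1 by the change (4-chlorophenyl in place of pyridin-3-yl on an aromatic carbon). Going by the values given here, no measured step touches the same place or the same pair of groups, so the expectation rests only on the spread of the three numbers, which is narrow. Compound 4 is therefore expected to show a step of about a 1.1-fold higher number from compound 1 to compound 4 (0.05 log units; within the scatter), that is, no change beyond the scatter. Compound 4 is estimated at 25000 nM, within a range from 8000 nM to 80000 nM.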

Compound 4, half-maximal inhibitory concentration: 20900 nM
Estimate against measurement, compound 4: 1.2-fold (0.08 log units) above, and the stated range covers the measured number.
By their numbers in this assay, from the lowest: compounds 4, 3 and 1 (each within the scatter of the next); then compound 2.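

In this assay, exchanging pyridin-3-yl for 4-chlorophenyl on the aromatic carbon next to the ring nitrogen gives a step of a 1.1-fold lower number from compound 1 to compound 4 (0.03 log units; within the scatter) and so stays within the scatter. Among the compounds shown here, the earlier compounds had offered a single-place step only at the thiophene attachment, so this is the first reading at this position, and it shows that the ring nitrogen and the hydrogen-bond acceptor counted for pyridin-3-yl can be absent here without a change beyond the scatter. No independent measurement explains this result.

On these data alone, whether an open-chain group at this position, such as an aminomethyl group or a carboxylic acid, would also leave the number within the scatter remains open. So does whether 4-chlorophenyl would give a similar step alongside the thiophen-3-yl group of compound 3.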